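Trading Fluoro for Hydrogen on the Fused Ring System

This account rests on a few compounds, and the source may have more. Where it says the series, first, only, none or still open, it means among the compounds named here.

Measured compounds:
compound 1 `O=C(COc1ccc(CN2CC=C(c3c[nH]c4ccc(F)cc34)CC2)cc1)NO` gives 949 nM
compound 2 `O=C(COc1ccc(CN2CC=C(c3c[nH]c4ccc(F)cc34)CC2)c(F)c1)NO` reaches only a limit of the assay, > 5000 nM
compound 3 `Cc1[nH]c2cccc(F)c2c1C1=CCC(NCc2ccc(OCC(=O)NO)cc2F)CC1` gives 254 nM

In a functional assay on HCT-116 cells (Homo sapiens) for antiproliferative activity, with a stated time of 72 h (on this read-out lower numbers stand for stronger inhibition and higher numbers for weaker inhibition), compound 1 gives 949 nM. For compound 2 the assay reports no number but a limit, (the limit of > 5000 nM in this assay, at which 1 of the 3 values shown sits). The two differ by one change, (hydrogen in place of fluoro on an aromatic carbon), and that change gives an at least 5.2-fold lower number from compound 2 to compound 1 (0.72 log units; beyond the scatter). Compound 3 gives the lowest of the two numbers, and the difference between the core of compound 3 and the core of compound 2 is not broken down here.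

Compound 4 `Cc1[nH]c2ccccc2c1C1=CCC(NCc2ccc(OCC(=O)NO)cc2F)CC1` has not been measured. It differs from compound 3 by hydrogen in place of fluoro on an aromatic carbon. This is the same kind of change as that from compound 2 to compound 1, but not the same: there the fluoro sat ortho to a large group and meta to a (hydroxycarbamoyl)methoxy group, while here it sits on a ring that is part of a fused or bridged system of two rings, ortho to a fused ring and meta to a fused ring. The earlier step, an at least 5.2-fold lower number from compound 2 to compound 1 (0.72 log units; beyond the scatter), is therefore only a loose guide. Because compound 3 gives 254 nM and the change touches a different part of the molecule, compound 4 is expected to give 400 nM, a step estimated as a 1.6-fold higher number from compound 3 to compound 4 (0.20 log units; within the scatter), with an expected range from 150 nM to 1200 nM.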

Compound 4, half-maximal inhibitory concentration: 99 nM
Beside the measured number, compound 4's estimate is 4.0-fold (0.61 log units) above it; measured number outside the range, below it.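

In this assay, putting hydrogen in place of the fluoro on the fused ring system gives a 2.6-fold lower number from compound 3 to compound 4 (0.41 log units; beyond the scatter), so the same kind of change again lowers the number, now on a second core and at a different place in the molecule: the same change on two cores in this assay, an at least 5.2-fold lower number (0.72 log units; beyond the scatter) from compound 2 to compound 1 and a 2.6-fold lower number (0.41 log units; beyond the scatter) from compound 3 to compound 4; the limit leaves it open whether they differ. Going by these compounds, compound 2 stands at > 5000 nM, which is a limit of the assay and not a number, so the size of the step on that core remains unknown, and nothing can be said about whether the change counts for more on one core than on the other. The direction of the step therefore carried over in these two pairs, but two pairs make no rule for other cores, and they do not give a size that could be transferred from one core to the next.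

Compound 4 still carries a second fluoro on its other aromatic ring, and the compounds shown leave open what hydrogen in its place would give on this core. They also leave open whether a chloro, a methyl or a methoxy group on the aromatic carbon that held the fluoro in compound 3 would go the same way as hydrogen.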